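The source may report more compounds than this note shows. Statements on the series, on what has been measured and on what is new or still open speak of the compounds shown alone.

The shared core appears in compound 1 `c1ccc2c(-c3cnc4[nH]nc(-c5nc6ccccc6[nH]5)c4c3)cncc2c1` and in compound 2 `CC(C)NCc1cccc2[nH]c(-c3n[nH]c4ncc(-c5cncc6ccccc56)cc34)nc12`. In an assay on isolated protein for inhibition of proto-oncogene tyrosine-protein kinase receptor Ret (Homo sapiens) (on this read-out higher numbers stand for weaker inhibition and lower numbers for stronger inhibition), compound 1 gives "not determined" (no result reported), so no number stands for it. For compound 2 this assay reports only a limit, > 100000 nM, which marks the edge of what the measurement can register rather than a number. Compound 2 thus sits at the limit of > 100000 nM in this assay, at which 1 of the 2 values shown sits. Compound 3 `CCN(CC)C(=O)c1cccc2[nH]c(-c3n[nH]c4ncc(-c5cncc6ccccc56)cc34)nc12` differs from compound 2 in one place: diethylcarbamoyl in place of (isopropylamino)methyl on an aromatic carbon. No measured pair shows the effect of such a change, so the step has no precedent among these compounds. The expected step is a step that the limit leaves unreadable from compound 2 to compound 3, none beyond the usual scatter, with a strong chance that this assay again records only a limit. Compound 3 is therefore estimated at 150000 nM, within a range from 30000 nM to 1000000 nM.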

Compound 3, half-maximal inhibitory concentration: 1230 nM
Compound 3: the middle estimate sits 120-fold (2.09 log units) above what was measured; measured number outside the range, below it.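

Placing diethylcarbamoyl in place of (isopropylamino)methyl on this aromatic carbon gives, in this assay, an at least 81-fold lower number from compound 2 to compound 3 (1.91 log units; beyond the scatter), a change beyond the usual scatter. Within the data shown here, the group on this carbon can therefore decide whether the shared core registers as an inhibitor of measurable strength, and compound 3 gives the first single number. The full size of the step stays unknown because compound 2 reaches only a limit: the limit of > 100000 nM in this assay, at which 1 of the 3 values shown sits.

The swap changes both the linking unit and the alkyl part of the group at once, and compound 1, which lacks any such group, has no result, so neither the source of the gain nor the effect of the group itself can be read. A smaller dimethylcarbamoyl group or a carboxylic acid on the same carbon would help separate these contributions.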